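A few compounds are considered here, and "the series" means these few. Any claim that something is new, unique, unknown or untested is made for them only; others in the source may bear on it.

Compound 1 `O=C(NCCCNc1cc(-c2cn(-c3ccccc3)nc2-c2cccc(O)c2)ccn1)Nc1ccc(F)cc1` gives 3610 nM in a functional assay on 786-0 cells (Homo sapiens) for antiproliferative activity, read by sulforhodamine B assay, with a stated time of 48 h (on this read-out lower numbers stand for stronger inhibition of growth and higher numbers for weaker inhibition of growth), and stands level with compound 2 `O=C(NCCCNc1cc(-c2cn(-c3ccccc3)nc2-c2cccc(O)c2)ccn1)Nc1cccc(C(F)(F)F)c1` which gives 3710 nM on the same read-out. These two values lie within the scatter of each other, so neither compound stands apart. Compound 3 `COc1cccc(-c2nn(-c3ccccc3)cc2-c2ccnc(NCCCNC(=O)Nc3ccc(F)cc3)c2)c1` has yet to be measured. It differs from compound 1 in one place: methyl in place of hydrogen on an oxygen on an aromatic ring is the counted change, methyl in place of hydrogen on an oxygen on an aromatic ring, which turns 3-hydroxyphenyl into 3-methoxyphenyl. Among the compounds with values here, the only measured step, a 1.0-fold higher number from compound 1 to compound 2 (0.01 log units; within the scatter) for 3-(trifluoromethyl)phenyl in place of 4-fluorophenyl on an amide-type nitrogen, stayed within the scatter. That step lies at another place in the molecule, however, and bears only indirectly on this change. Within the data shown here, no measured pair covers hydroxy to methoxy, so the expectation rests on little. The expected step is a 1.4-fold higher number from compound 1 to compound 3 (0.14 log units; within the scatter) in this assay and would lean toward weaker inhibition of growth, within the scatter or little beyond it. For compound 3 the estimated value is 5000 nM with an expected range from 2200 nM to 12000 nM once it is measured.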

Compound 3, concentration for total growth inhibition: > 37000 nM
Compound 3: no number, only a limit (the forecaster's own chance of this, stated with the estimate: 10%); middle value at least 7.4-fold (0.86 log units) from the limit.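

Methyl in place of hydrogen on the oxygen of the 3-hydroxyphenyl group gives an at least 10-fold higher number from compound 1 to compound 3 (1.01 log units; beyond the scatter) in this assay, while the only earlier step, a 1.0-fold higher number from compound 1 to compound 2 (0.01 log units; within the scatter), came from a change at another place in the molecule. Within the data shown here, this pair therefore shows what the earlier compounds could not: the read-out responds strongly to the change from hydroxy to methoxy, even though it stayed within the scatter for the one change seen before. Compound 3 carries a limit and not a number, so the full size of this step stays unknown: the limit of > 37000 nM in this assay, at which 1 of the 3 values shown sits.

The compounds shown leave open whether an amine or a carboxylic acid in place of the hydroxy, or a longer chain such as ethoxy on the oxygen, would stand nearer to compound 1 or to compound 3. Also open, going by these compounds, are whether the same methyl would have a like effect alongside the 3-(trifluoromethyl)phenyl group of compound 2, and what lies behind the step, since no measured property bears on its cause.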